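This account rests on a few compounds, and the source may have more. Where it says the series, first, only, none or still open, it means among the compounds named here.

In an assay on HL-60 cells for agonist activity at vitamin D3 receptor (Homo sapiens), read by microscopy, with a stated time of 96 h (on this read-out lower numbers stand for an effect already at smaller amounts and higher numbers for an effect only at larger amounts of compound), compound 2 `CCn1c(C(=O)N(C)CCC#N)ccc1C(CC)(CC)c1ccc(OCC(O)C(C)(C)C)c(C)c1` gives 1960 nM, the lowest of the two numbers obtained so far. Compound 1 `CCn1c(C(=O)N(C)CCC#N)ccc1C(CC)(CC)c1ccc(OCC(=O)C(C)(C)C)c(C)c1` gives 9800 nM, and a 5.0-fold lower number from compound 1 to compound 2 (0.70 log units; beyond the scatter). Compound 3 `CCOc1ccc(NC(=O)c2ccc(C(CC)(CC)c3ccc(OCC(=O)C(C)(C)C)c(C)c3)n2CC)cc1` reaches only a limit of the assay, > 50000 nM. That step, an at least 5.1-fold higher number from compound 1 to compound 3 (0.70 log units; beyond the scatter), rests on (the limit of > 50000 nM in this assay, at which 1 of the 3 values shown sits). Compound 4 `CCn1c(C(=O)OCc2ccc(F)cc2)ccc1C(CC)(CC)c1ccc(OCC(O)C(C)(C)C)c(C)c1` is not yet measured; it differs from compound 2 thus: (4-fluorobenzyl)oxy in place of (2-cyanoethyl)(methyl)amino on a carbonyl carbon. Among the compounds with values here, the one measured step at the carbonyl carbon also replaced the same amine, and a weaker result is expected for compound 4 because an at least 5.1-fold higher number from compound 1 to compound 3 (0.70 log units; beyond the scatter), although the new group is an ester rather than an anilide. For compound 4 the expected step is a 3.1-fold higher number from compound 2 to compound 4 (0.49 log units; beyond the scatter). Compound 4 is estimated at 6000 nM, within a range from 1500 nM to 30000 nM.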

Compound 4, half-maximal effective concentration: > 50000 nM
Compound 4: only a limit was reported (the forecaster's own chance of this, stated with the estimate: 25%); at least 8.3-fold (0.92 log units) between middle value and limit.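

Replacing (2-cyanoethyl)(methyl)amino on the carbonyl carbon gives an at least 25-fold higher number from compound 2 to compound 4 (1.40 log units; beyond the scatter) in this assay, so the loss seen with the anilide compound 3 also appears with an ester. It also appears on the hydroxyl-bearing side chain of compound 2, so that hydroxyl does not offset this change. The step is only a lower bound, as compound 4 reached a limit: the limit of > 50000 nM in this assay, at which 2 of the 4 values shown sit.

Going by these compounds, whether the loss follows the ester oxygen or the added aromatic ring stays open. A (4-fluorobenzyl)amino or a small dimethylamino group on the same carbonyl carbon would help separate the two.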